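N-Alkyl extension on the sulfonamide nitrogen of the shared core

The source may report more compounds than this note shows. Statements on the series, on what has been measured and on what is new or still open speak of the compounds shown alone.

Measured compounds:
compound 1 `COc1cccc(N(C)S(=O)(=O)C2CC3OC2C(c2ccc(NC(=O)CCCCCCC(=O)O)cc2)=C3c2ccc(O)cc2)c1` — 62200 nM
compound 2 `CN(c1ccccc1Cl)S(=O)(=O)C1CC2OC1C(c1ccc(NC(=O)CCCCCCC(=O)O)cc1)=C2c1ccc(O)cc1` — 73500 nM

Both compounds were read in a functional assay on DU-145 cells (Homo sapiens) for antiproliferative activity, read by MTT assay, with a stated time of 72 h; on this read-out higher numbers stand for weaker inhibition and lower numbers for stronger inhibition. Compound 2 stands at the highest of the two numbers; its nearest neighbour is compound 1, and the step of a 1.2-fold higher number from compound 1 to compound 2 (0.07 log units; within the scatter) lies within the scatter, so the two are not separated on this read-out.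

Compound 3 `CCN(c1ccccc1Cl)S(=O)(=O)C1CC2OC1C(c1ccc(NC(=O)CCCCCCC(=O)O)cc1)=C2c1ccc(O)cc1` is the next compound of the series and has not yet been measured. It differs from compound 2 by methyl in place of hydrogen on a saturated chain carbon bound to a sulfonamide nitrogen. Put one bond further out, this reads methyl to ethyl, that is (2-chlorophenyl)(methyl)amino to (2-chlorophenyl)(ethyl)amino.

For the measured compounds named here, the only measured step, a 1.2-fold higher number from compound 1 to compound 2 (0.07 log units; within the scatter), concerns the aryl group on the sulfonamide nitrogen, not the alkyl group, and it was within the scatter. Going by the values given here, no measured step probes the alkyl position itself. Among the compounds with values here, both measured values sit in the same weak region, and the series so far shows no movement beyond the scatter. For compound 3 in this assay the expectation is therefore a step of a 1.1-fold lower number from compound 2 to compound 3 (0.02 log units; within the scatter), that is no change beyond the scatter, with an estimated value of 70000 nM and a range from 30000 nM to 160000 nM.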

Compound 3, half-maximal inhibitory concentration: > 100000 nM
Compound 3 was reported as a limit (the forecaster's own chance of this, stated with the estimate: 15%); middle value at least 1.4-fold (0.15 log units) from the limit.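

In this assay compound 3 is reported only as a limit, not as a number: the limit of > 100000 nM in this assay, at which 1 of the 3 values shown sits.

This is the first change at the alkyl position on the sulfonamide nitrogen, and methyl to ethyl gives an at least 1.3-fold higher number from compound 2 to compound 3 (0.13 log units; that floor lies within the scatter), so only a floor is known and the two compounds are not shown to be separated. The wider replacement, (2-chlorophenyl)(ethyl)amino in place of (3-methoxyphenyl)(methyl)amino on a sulfonyl sulfur, gives an at least 1.6-fold higher number from compound 1 to compound 3 (0.20 log units; that floor lies within the scatter), again only a floor within the scatter. Where compound 1 and compound 2 both gave numbers, the ethyl member gives none, so this position has so far yielded no measured size of effect, only the finding that this small extension brings no gain that can be read on this scale.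

On these data alone, what a propyl chain, a benzyl group or a 2-hydroxyethyl group on the sulfonamide nitrogen would give in this assay stays open. Also open, as far as these compounds go, is whether ethyl behaves the same with the 3-methoxyphenyl group in place of the 2-chlorophenyl group, and whether a hydroxamic acid at the end of the chain in place of the carboxylic acid would move the series out of this weak region.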